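A few compounds are considered here, and "the series" means these few. Any claim that something is new, unique, unknown or untested is made for them only; others in the source may bear on it.

Compound 1, `COC(=O)c1ccc(NCc2cncn2Cc2cccc(C)c2)cc1-c1ccccc1`, was measured in a toxicity assay on NIH3T3 cells (Mus musculus) for cytotoxicity, read by resazurin assay; on this read-out higher numbers stand for an effect only at larger amounts of compound and lower numbers for an effect already at smaller amounts. Compound 1 gives > 10000 nM there, which is a limit of the assay rather than a number. Compound 2, `COC(=O)c1ccc(NCc2cncn2Cc2ccc(OC)cc2)cc1-c1ccccc1`, shares the core and in this assay compound 2 gives "not determined" (no result reported), so no number stands for it. Among the compounds with values here, the one other value shown for this series, that of compound 1, is a limit, as recorded in the limit of > 10000 nM in this assay, at which 1 of the 2 values shown sits. Compound 3, `COC(=O)c1ccc(NCc2cncn2Cc2ccc(F)cc2F)cc1-c1ccccc1`, is not yet measured. Its change from compound 2 is 2,4-difluorophenyl in place of 4-methoxyphenyl on a saturated chain carbon bound to an aromatic nitrogen. Within the data shown here, with no measured step between two compounds available, no size or direction beyond the usual scatter of this assay can be read from the data, and nothing in the two compounds so far suggests a shift. Compound 3 is expected to give about 20000 nM in this assay, within a range of 5000 nM to 100000 nM, and it is expected that the assay may again report only a limit.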

Compound 3, half-maximal effective concentration: > 1000 nM
Compound 3: no number, only a limit; the forecaster's own chance of this, stated with the estimate: 70%; the middle value is on the limit's open side.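

Within the data shown here, compound 1 and compound 3 each stand only as a limit in this assay, so no step between them can be read. The compounds shown leave open whether compound 1 and compound 3 differ at all in this assay, and at what amount of compound either shows an effect.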